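Indole-fused bicyclic amides: sulfonamide replacement at the ring nitrogen

This account rests on a few compounds, and the source may have more. Where it says the series, first, only, none or still open, it means among the compounds named here.

Measured compounds:
compound 1 `CC(=O)N(C)c1ccc2[nH]c(-c3n[nH]c4ccccc34)cc2n1`, 10300 nM
compound 2 `CN(C(=O)c1ccc(Cl)cc1)c1ccc2[nH]c(-c3n[nH]c4ccccc34)cc2n1`, 630 nM
compound 3 `CN(C(=O)c1ccccc1)c1ccc2[nH]c(-c3n[nH]c4cc(Cl)ccc34)cc2n1`, 5590 nM

In a functional assay on KB cells (Homo sapiens) for antiproliferative activity, read by MTT assay, with a stated time of 72 h (on this read-out lower numbers stand for stronger inhibition and higher numbers for weaker inhibition), compound 2 gives the lowest number of the three. Its nearest neighbour is compound 3 with 5590 nM, and compound 1 lies furthest with 10300 nM. Among the compounds with values here, the one single-point step in the set, a 16-fold lower number from compound 1 to compound 2 (1.21 log units; beyond the scatter), shows that an aromatic ring on the carbonyl carbon in place of a methyl group brings a large improvement.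

Compound 4 `CN(c1ccc2[nH]c(-c3n[nH]c4ccccc34)cc2n1)S(=O)(=O)c1ccc(Br)cc1` is not yet measured. It differs from compound 2 by (4-bromophenyl)sulfonyl in place of (4-chlorophenyl)carbonyl on a nitrogen on an aromatic ring. Within the data shown here, no measured pair isolates the exchange of a carbonyl for a sulfonyl group, nor a bromine for a chlorine on that ring, so the step from compound 1 to compound 2 bears on it only indirectly: it indicates that an aromatic ring at this position is retained here, which argues against a collapse back towards compound 1. Whether the sulfonyl linker holds or loses potency is open. A modest rise in number is expected, giving an estimated step of a 2.4-fold higher number from compound 2 to compound 4 (0.38 log units; beyond the scatter) in this assay. Compound 4 is therefore estimated at 1500 nM, with a range from 400 nM to 6000 nM.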

Compound 4, half-maximal inhibitory concentration: 7150 nM
Beside the measured number, compound 4's estimate is 4.8-fold (0.68 log units) below it; measured number above the stated range.
By their numbers in this assay, from the lowest: compound 2; then compounds 3, 4 and 1 (each within the scatter of the next).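

In this assay, an aromatic ring on this nitrogen is not enough on its own: both groups hold one six-membered aromatic ring of carbon only, yet (4-bromophenyl)sulfonyl in place of (4-chlorophenyl)carbonyl gives an 11-fold higher number from compound 2 to compound 4 (1.05 log units; beyond the scatter). Set against the acetyl group, the same sulfonyl group gives a 1.4-fold lower number from compound 1 to compound 4 (0.16 log units; within the scatter), so compound 4 cannot be told apart from compound 1, and the gain seen in a 16-fold lower number from compound 1 to compound 2 (1.21 log units; beyond the scatter) does not carry over to compound 4. This place on the nitrogen therefore responds to the linking group, the halogen or both, and not merely to the presence of an aromatic ring.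

The shown compounds do not separate the exchange of carbonyl for sulfonyl from that of chlorine for bromine, so the share of each in the loss stays open, as does the outcome with an amine or a longer chain between the nitrogen and the aromatic ring. Nothing available on these compounds accounts for the loss of potency with the sulfonyl group.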